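Shortening the phosphate chain on two uracil nucleotides

The compounds below may be only part of what the source reports. "The series", "measured", "known", "first", "only" and "open" are said of these compounds alone.

Compound 1 `O=c1ccn([C@@H]2O[C@H](COP(=O)(O)OP(=O)(O)OP(=O)(O)O)[C@@H](O)[C@H]2O)c(=S)[nH]1` is tested in an in vitro functional assay on 1321-N1 cells for agonist activity at P2Y purinoceptor 2 (Homo sapiens) (on this read-out higher numbers stand for an effect only at larger amounts of compound and lower numbers for an effect already at smaller amounts), where compound 1 gives 50 nM. Compound 2 `O=c1ccn([C@@H]2O[C@H](COP(=O)(O)OP(=O)(O)O)[C@@H](O)[C@H]2O)c(=S)[nH]1` carries one change, (a hydrogen atom in place of a group of 4 heavy atoms (3 oxygen, 1 phosphorus; no ring), on an oxygen). In this assay compound 2 reaches only a limit, > 1000 nM. The step is an at least 20-fold higher number from compound 1 to compound 2 (1.30 log units; beyond the scatter). Compound 3 `Cn1c(=O)ccn([C@@H]2O[C@H](COP(=O)(O)OP(=O)(O)O)[C@@H](O)[C@H]2O)c1=O` has a different core; the difference between the two cores is not broken down here. In this assay compound 3 also reaches only a limit, > 1000 nM. Compound 4 `Cn1c(=O)ccn([C@@H]2O[C@H](COP(=O)(O)O)[C@@H](O)[C@H]2O)c1=O` differs from compound 3 by the same change, (a hydrogen atom in place of a group of 4 heavy atoms (3 oxygen, 1 phosphorus; no ring), on an oxygen). Compound 4 is expected to stay at or beyond the limit of > 1000 nM in this assay, at which 2 of the 3 values shown sit, because compound 3 already sits there, so the expected step is a step that the limit leaves unreadable from compound 3 to compound 4. For compound 4 the estimated value in this assay is 10000 nM, expected between 1000 nM and 100000 nM.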

Compound 4, half-maximal effective concentration: > 100000 nM
Compound 4: only a limit was reported; the forecaster's own chance of this, stated with the estimate: 90%; at least 10-fold (1.00 log units) between middle value and limit.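

Compound 3 and compound 4 each give only a limit in this assay, so the step between them cannot be read. The compounds shown leave open whether shortening the phosphate chain of compound 3 changes its effect at all.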